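The source may hold more compounds than are shown below. What is called first, only, known or untested is meant among the compounds shown, and "the series" means these compounds.

Among the compounds with values here, in an in vitro ADME assay on microsomes from liver (Simiiformes) (on this read-out higher numbers stand for a longer-lived compound and lower numbers for a shorter-lived compound), compound 1 `Cc1cc(CCCOc2c(C)cc(-c3noc(C)n3)cc2C)on1` gives 0.45 h, and compound 2 `CCc1cc(CCCOc2c(C)cc(-c3noc(C)n3)cc2C)on1` gives 0.183 h, the lowest number among the three compounds measured so far. For compound 3 `CCOCc1cc(CCCOc2c(C)cc(-c3noc(C(F)(F)F)n3)cc2C)on1`, the assay reports only a limit and not a number, > 2.5 h. Within the data shown here, no single-place step links compound 3 to the other two.

The next compound to be read in this assay is compound 4 `CCc1cc(CCCOc2c(C)cc(-c3noc(C4CC4)n3)cc2C)on1`, which departs from compound 2 as follows: cyclopropyl in place of methyl on an aromatic carbon. In words, cyclopropyl stands in place of methyl on an aromatic carbon of a five-membered aromatic ring with 2 nitrogen and 1 oxygen.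

Among the measured compounds shown here, the one measured step is a 2.5-fold lower number from compound 1 to compound 2 (0.39 log units; beyond the scatter). It is a modest change, beyond the scatter. The structural difference in this step is methyl in place of hydrogen on a saturated chain carbon bound to an aromatic carbon. For the measured compounds named here, that is a different place in the structure, so it offers only a loose guide, and no measured step covers the change at the ring itself. No shift beyond the scatter is therefore expected, and the estimated step is a 1.1-fold lower number from compound 2 to compound 4 (0.03 log units; within the scatter). The half-life of compound 4 is estimated at 0.17 h, with an expected range from 0.07 h to 0.4 h.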

Compound 4, half-life: 0.9 h
Compound 4: the middle estimate sits 5.3-fold (0.72 log units) below what was measured; measured number outside the range, above it.
By their numbers in this assay, from the lowest: compound 2; then compounds 1 and 4 (each within the scatter of the next). At a limit, above all of these: compound 3.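

In this assay, within the data shown here, the change from 5-methyl-1,2,4-oxadiazol-3-yl to 5-cyclopropyl-1,2,4-oxadiazol-3-yl gives a 4.9-fold higher number from compound 2 to compound 4 (0.69 log units; beyond the scatter), so the group on this aromatic carbon of the five-membered aromatic ring with 2 nitrogen and 1 oxygen has a real bearing on the half-life, which no earlier step could show. Among these compounds, the direction runs against the only earlier step, a 2.5-fold lower number from compound 1 to compound 2 (0.39 log units; beyond the scatter), which lay at a different place, on a saturated chain carbon bound to an aromatic carbon, so the half-life responds to changes at both places and not in the same direction. Compound 3 alone stands at a limit and not at a number, and the step at this ring stays clear of it: the limit of > 2.5 h in this assay, at which 1 of the 4 values shown sits.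

The compounds shown give no reason for the step, and they cannot separate the closed three-membered ring from the added carbon count, which an isopropyl or a cyclobutyl group at this place would help to do. From the compounds shown here alone, whether cyclopropyl gives a similar step on the core of compound 1, with its methyl in place of ethyl, also remains open.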